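The source may hold more compounds than are shown below. What is called first, only, known or untested is meant among the compounds shown, and "the series" means these compounds.

Measured compounds in an assay on isolated protein for displacement of a labelled ligand from metabotropic glutamate receptor 5 (Homo sapiens), with a stated time of 60 min, tested at 1 uM; on this read-out lower numbers stand for less inhibition and higher numbers for more inhibition at the one concentration tested (going by the name of the read-out):
compound 1 `Cc1ccc(S(=O)(=O)c2cnc3ccc(Cl)cc3c2N2CCC(C)CC2)cc1F` gives 68%
compound 2 `COc1ccc(S(=O)(=O)c2cnc3ccc(Cl)cc3c2N2CCC(C)CC2)cc1Cl` gives 46%
compound 3 `CC1CCN(c2c(S(=O)(=O)c3ccc(C#N)cc3)cnc3ccc(Cl)cc23)CC1` gives 31%

On these numbers compound 3 stands lowest of the three, with compound 2 nearest and compound 1 furthest above it. Compound 4 `CC1CCN(c2c(S(=O)(=O)c3cccc(C#N)c3)cnc3ccc(Cl)cc23)CC1` differs from compound 3 only in the aryl group on the sulfonyl sulfur: 3-cyanophenyl in place of 4-cyanophenyl on a sulfonyl sulfur. Every measured step also changes that aryl group: a number 22 percentage points lower from compound 1 to compound 2 (beyond the scatter), a number 37 percentage points lower from compound 1 to compound 3 (beyond the scatter), and a number 15 percentage points lower from compound 2 to compound 3 (beyond the scatter). Within the data shown here, none of them, however, keeps the nitrile and only moves it on the ring, so no step bears directly on this change; the measured steps only show that the aryl group matters. A modest step in either direction, or none beyond the scatter, seems plausible, so compound 3's value is taken as the anchor. The estimate for compound 4 in this assay is 35%, expected between 15% and 55%, which amounts to an expected step of a number 4 percentage points higher from compound 3 to compound 4 (within the scatter).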

Compound 4, a percentage reported as inhibition, at one concentration (the size of the read-out at that concentration, not a potency): 90%
Beside the measured number, compound 4's estimate is 55 percentage points below it; the measured number lies above the stated range.
By their numbers in this assay, from the lowest: compound 3; then compound 2; then compound 1; then compound 4.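

In this assay the swap of 3-cyanophenyl for 4-cyanophenyl gives a number 59 percentage points higher from compound 3 to compound 4 (beyond the scatter) with the same atoms joined differently, so where the nitrile sits on the ring matters, not only which aryl group is present. The 3-cyanophenyl group also outdoes both substituted aryl groups, with a number 44 percentage points higher from compound 2 to compound 4 (beyond the scatter) and a number 22 percentage points higher from compound 1 to compound 4 (beyond the scatter) as the steps. No evidence here explains the size of this shift.

Going by these compounds, whether an amine or a carboxylic acid in place of the nitrile would keep this high number remains open. A reading at one concentration also leaves the potency of compound 4 unknown.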